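Swapping the trimethoxyphenyl for a chloro-fluorophenyl group

A few compounds are considered here, and "the series" means these few. Any claim that something is new, unique, unknown or untested is made for them only; others in the source may bear on it.

The two measured compounds share one core and differ only in the aryl group attached to a nitrogen on an aromatic ring. Compound 1 `C=CC(=O)Nc1cccc(NC(=O)CSc2nc(Nc3cccc(Cl)c3)c3ccccc3n2)c1` carries a 3-chlorophenyl group there, and in a functional assay on NCI-H1975 cells (Homo sapiens) for inhibition, read by MTT assay, with a stated time of 72 h (on this read-out higher numbers stand for weaker inhibition and lower numbers for stronger inhibition), compound 1 gives 9460 nM. Compound 2 `C=CC(=O)Nc1cccc(NC(=O)CSc2nc(Nc3cc(OC)c(OC)c(OC)c3)c3ccccc3n2)c1` carries a 3,4,5-trimethoxyphenyl group instead. In this assay compound 2 reaches only > 50000 nM, which is a limit of the assay rather than a number. The change an at least 5.2-fold higher number from compound 1 to compound 2 (0.72 log units; beyond the scatter) therefore rests on (the limit of > 50000 nM in this assay, at which 1 of the 2 values shown sits), so the size of the loss can only be bounded from below.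

Compound 3 `C=CC(=O)Nc1cccc(NC(=O)CSc2nc(Nc3ccc(F)c(Cl)c3)c3ccccc3n2)c1` is not yet measured. It differs from compound 2 by 3-chloro-4-fluorophenyl in place of 3,4,5-trimethoxyphenyl on a nitrogen on an aromatic ring. This brings the aryl group back close to that of compound 1, keeping the chloro substituent and adding a fluorine. Since the measured step from compound 1 to compound 2 was at least modest and the trimethoxyphenyl group now leaves, compound 3 is expected to return toward the range of compound 1, an estimated step of an at least 5.0-fold lower number from compound 2 to compound 3 (0.69 log units; beyond the scatter). The expected value for compound 3 in this assay is 10000 nM, with a likely range from 3000 nM to 40000 nM.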

Compound 3, half-maximal inhibitory concentration: > 50000 nM
Compound 3: a limit, no number (the forecaster's own chance of this, stated with the estimate: 20%); middle value at least 5.0-fold (0.69 log units) from the limit.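

In this assay compound 3 gives > 50000 nM, which is a limit of the assay and not a number. Going by these compounds alone, its only difference from compound 1 is fluoro in place of hydrogen on an aromatic carbon, yet that single change gives an at least 5.2-fold higher number from compound 1 to compound 3 (0.72 log units; beyond the scatter), so at this position on the nitrogen a large group with three methoxy substituents is not needed for the number to climb out of the measurable range. The step from compound 2 to compound 3 cannot be read, and nothing separates the 3,4,5-trimethoxyphenyl and 3-chloro-4-fluorophenyl groups in this read-out, with compound 1 the only one of the three that gives a number: the limit of > 50000 nM in this assay, at which 2 of the 3 values shown sit.

From the compounds shown here alone, how far compound 2 and compound 3 lie past that limit stays unknown, so it remains open which of the two changes costs more. It is also open how this position responds to a plain phenyl group, or to a phenyl group carrying a methyl group or an amine, since only these three aryl groups are shown on the shared core.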